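From phenyl to 4-methoxyphenyl in a two-compound series

The source may report more compounds than this note shows. Statements on the series, on what has been measured and on what is new or still open speak of the compounds shown alone.

Compound 1 (`C/C1=C\CC[C@@]2(C)O[C@@H]2[C@H]2OC(=O)[C@@H](CN(C)CCN(C)C)[C@@H]2C[C@H]1O`) and compound 2 (`C/C1=C\CC[C@@]2(C)O[C@@H]2[C@H]2OC(=O)[C@@H](CN3CCN(c4ccccc4)CC3)[C@@H]2C[C@H]1O`) share one core. In a functional assay on Hs 683 cells (Homo sapiens) for inhibition, read by colorimetric assay and MTT assay, with a stated time of 72 h (a higher number here means a weaker inhibitor, a lower number a stronger inhibitor), compound 1 gives 9000 nM and compound 2 gives 22000 nM as the higher of the two numbers. Compound 2 is therefore the weaker inhibitor of the pair, and the gap lies beyond the scatter. Compound 3 (`COc1ccc(N2CCN(C[C@@H]3C(=O)O[C@H]4[C@H]3C[C@@H](O)/C(C)=C/CC[C@@]3(C)O[C@H]43)CC2)cc1`) carries methoxy in place of hydrogen on an aromatic carbon, para to a large group (methoxy in place of hydrogen on an aromatic carbon). Among the compounds with values here, no measured pair yet shows a change at this place, so the expectation rests on compound 2 alone, with its 22000 nM as the starting point. The estimated step of a 1.2-fold lower number from compound 2 to compound 3 (0.09 log units; within the scatter) is expected to be slightly downward and to stay within the scatter in this assay. For compound 3 the estimated value is 18000 nM, with an expected range (8000 nM to 40000 nM).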

Compound 3, half-maximal inhibitory concentration: 22000 nM
Compound 3: the middle estimate sits 1.2-fold (0.09 log units) below what was measured, within the range that was stated.
By their numbers in this assay, from the lowest: compound 1; then compounds 2 and 3 (each within the scatter of the next).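

In this assay, phenyl to 4-methoxyphenyl gives no change at the digits printed from compound 2 to compound 3 (within the scatter). Within the data shown here, this is the first reading at this place, on an aromatic carbon para to a large group, and it shows that methoxy in place of hydrogen leaves the number unmoved. No measured property of these compounds bears on this result, so the flat step stands as an observation without an explanation.

Methoxy is the only replacement shown at this place, so it remains open whether an amine, a carboxylic acid or a longer chain there would shift the number beyond the scatter. Also open, on these data alone, is whether the same flat step would hold in cell lines other than this one.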